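The source may hold more compounds than are shown below. What is called first, only, known or untested is meant among the compounds shown, and "the series" means these compounds.

The measured compounds:
compound 1, `COc1cc(-c2cc(/C=C/C(=O)c3ccc(N)cc3)[nH]n2)cc(OC)c1OC`, with 14%
compound 2, `COc1ccc(-c2cc(/C=C/C(=O)c3ccc(OC)c(OC)c3)[nH]n2)cc1`, with 39%

Both compounds were tested in a functional assay on SR cells (Homo sapiens) for cytotoxicity, read by sulforhodamine B assay, with a stated time of 48 h, tested at 1 uM; on this read-out lower numbers stand for a stronger effect and higher numbers for a weaker effect at the one concentration tested. On this read-out compound 1 gives 14%, the lowest of the two numbers and therefore the stronger effect of the pair, while compound 2 gives 39%, a number that lies beyond the usual scatter above that of compound 1. The two compounds differ in more than one place, so their gap cannot be traced to a single change.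

Compound 3, `COc1cc(-c2cc(/C=C/C(=O)c3ccc(Cl)c(Cl)c3)[nH]n2)cc(OC)c1OC`, has not yet been measured. It keeps the core of compound 1 and differs from it in one place only: 3,4-dichlorophenyl in place of 4-aminophenyl on a carbonyl carbon. Among the measured compounds shown here, no measured pair shows what this exchange does to the read-out, so the expectation rests on compound 1 alone and carries real uncertainty. The step of a number 16 percentage points higher from compound 1 to compound 3 (beyond the scatter) is expected to be a modest move toward a weaker effect, one that may still fall inside the scatter. Compound 3 is therefore estimated at 30%, within a range from 10% to 60%.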

Compound 3, a percentage reported as activity, at one concentration (the size of the read-out at that concentration, not a potency): 23%
Beside the measured number, compound 3's estimate is 7 percentage points above it; low and high end bracket the measured number.
By their numbers in this assay, from the lowest: compounds 1 and 3 (each within the scatter of the next); then compound 2.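

Among the compounds shown here, with the core of compound 1 held fixed, placing 3,4-dichlorophenyl on the carbonyl carbon in place of 4-aminophenyl gives, in this assay, a number 9 percentage points higher from compound 1 to compound 3 (within the scatter), and this is the first comparison here that isolates a single change. On this one pair, then, the exchange leaves no difference that can be told apart from ordinary repeat-to-repeat variation, even though the two groups are far from alike: 4-aminophenyl counts 1 hydrogen-bond donor and 1 hydrogen-bond acceptor, and 3,4-dichlorophenyl counts neither. No measured property of these groups accompanies the result, so the data offer no explanation for how closely the two compounds read.

As far as these compounds go, what remains open is how far this tolerance extends, since a single exchange cannot show whether other groups on the carbonyl carbon would also read like these two, such as a phenyl ring carrying a carboxylic acid or a longer chain in place of the ring. The gap to compound 2 also stays unexplained, as that compound differs from the others in more than one place and no single change can be held responsible.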